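Fluorophenyl carbamates on a chromene core: aortic activity

A few compounds are considered here, and "the series" means these few. Any claim that something is new, unique, unknown or untested is made for them only; others in the source may bear on it.

Compound 1 `CC(=O)Oc1ccc2c(c1)C(n1ccccc1=O)=CC(C)(C)O2` carries an acetate on the shared core; in a functional assay (aorta) with Rattus norvegicus as the target (on this read-out lower numbers stand for lower potency and higher numbers for higher potency (the scale is a negative logarithm)), compound 1 gives 5.6. Compound 2 `CC1(C)C=C(n2ccccc2=O)c2cc(OC(=O)Nc3ccccc3F)ccc2O1` replaces that acetate with a (2-fluorophenyl)carbamoyl group, and in this assay compound 2 gives 5.38. Within the data shown here, the single measured step, a number 0.22 log units lower from compound 1 to compound 2 (within the scatter), shows that the change from acetate to the (2-fluorophenyl)carbamoyl group made no difference beyond the scatter. Among the measured compounds shown here, compound 2 thus sits within the scatter of compound 1, the only other measured number.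

Compound 3 `CC1(C)C=C(n2ccccc2=O)c2cc(OC(=O)Nc3ccc(F)cc3)ccc2O1` differs from compound 2 by 4-fluorophenyl in place of 2-fluorophenyl on an amide-type nitrogen. For the measured compounds named here, no measured step covers this change; the one step available, from compound 1 to compound 2, concerns a different part of the structure and was itself within the scatter. A step of no more than scatter size is therefore expected, a number 0.02 log units higher from compound 2 to compound 3 (within the scatter), and compound 3 is estimated at 5.4 with a range of 4.9 to 5.9.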

Compound 3, logarithm of the reciprocal of the active concentration, log(1/C): 5.3
Estimate against measurement, compound 3: 0.10 log units above; the range from low to high includes it.
By their numbers in this assay, from the lowest: compounds 3, 2 and 1 (each within the scatter of the next).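

Exchanging 2-fluorophenyl for 4-fluorophenyl on the amide-type nitrogen gives a number 0.08 log units lower from compound 2 to compound 3 (within the scatter) in this assay and so does not separate the two fluorophenyl carbamates on this read-out. The replacement of methyl on the carbonyl carbon by (4-fluorophenyl)amino gives a number 0.30 log units lower from compound 1 to compound 3 (within the scatter) and, like the 2-fluorophenyl counterpart, stays level with the acetate within the scatter. Nothing available offers an explanation for these steps.

Going by these compounds, whether any group on the amide-type nitrogen can move the number beyond the scatter remains open, for instance unsubstituted phenyl, 4-methoxyphenyl or a longer alkyl chain. Also open, on these data alone, is how a carboxylic acid or an amine on that phenyl ring would read in this assay.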